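Series notes: aryl swap on the exocyclic double bond

The source may hold more compounds than are shown below. What is called first, only, known or untested is meant among the compounds shown, and "the series" means these compounds.

Compound 1 `CN(C)c1ccc(/C=C2\S/C(=N\c3csc(-c4ccc(Cl)cc4)c3)NC2=O)cc1` gives 1500 nM in a functional assay on HT-29 cells (Homo sapiens) for cytotoxicity, read by MTT assay, with a stated time of 72 h; a higher number here means a weaker inhibitor, a lower number a stronger inhibitor.
Compound 2 `O=C1N/C(=N/c2csc(-c3ccc(Cl)cc3)c2)S/C1=C\c1ccc2ccccc2c1` gives 3700 nM in this assay.
Compound 3 `O=C1N/C(=N/c2csc(-c3ccc(Cl)cc3)c2)S/C1=C\c1ccccn1` gives 11500 nM in this assay.

Compound 3 stands with the highest number of the three in this assay; compound 2 is nearest, with a step of a 3.1-fold higher number from compound 2 to compound 3 (0.49 log units; beyond the scatter), and compound 1 is furthest, with a step of a 7.7-fold higher number from compound 1 to compound 3 (0.88 log units; beyond the scatter). Compound 4 `COc1ccc(/C=C2\S/C(=N\c3csc(-c4ccc(Cl)cc4)c3)NC2=O)cc1OC` is not yet measured. It differs from compound 3 in one place: 3,4-dimethoxyphenyl in place of pyridin-2-yl on a double-bonded chain carbon bound to a double-bonded ring carbon. Among the measured compounds shown here, two measured steps bear on this change, since both end at compound 3 and both exchange a carbon-only aryl group for pyridin-2-yl at the same place: a 7.7-fold higher number from compound 1 to compound 3 (0.88 log units; beyond the scatter) and a 3.1-fold higher number from compound 2 to compound 3 (0.49 log units; beyond the scatter). Both ran to a higher number, so reversing the direction toward a carbon-only ring is expected to lower the number in this assay, beyond the scatter, by a modest step, as the two steps were. The estimate for compound 4 is therefore 3500 nM, with a range from 1200 nM to 10000 nM, which is an expected step of a 3.3-fold lower number from compound 3 to compound 4 (0.52 log units; beyond the scatter).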

Compound 4, half-maximal inhibitory concentration: 10900 nM
Compound 4: the middle estimate sits 3.1-fold (0.49 log units) below what was measured; measured number above the stated range.
By their numbers in this assay, from the lowest: compound 1; then compound 2; then compounds 4 and 3 (each within the scatter of the next).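

The exchange of pyridin-2-yl for 3,4-dimethoxyphenyl at this place gives a 1.1-fold lower number from compound 3 to compound 4 (0.02 log units; within the scatter) in this assay, so a six-membered aromatic ring of carbon only is not enough by itself to give a lower number here. The carbon-only groups also differ among themselves, with a 2.9-fold higher number from compound 2 to compound 4 (0.47 log units; beyond the scatter) and a 7.3-fold higher number from compound 1 to compound 4 (0.86 log units; beyond the scatter), so the number at this place follows the particular aryl group and not merely the absence of ring nitrogen. No measurement shown gives a reason for these differences.

The compounds shown leave open whether the lower number of compound 1 carries over to other amines on the phenyl ring, such as a piperidine or a primary amine. Also open, going by these compounds, is how a phenyl ring bearing one methoxy group or a carboxylic acid would read.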